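Dioxolane in place of hydroxyethyl on a triazole series

A few compounds are considered here, and "the series" means these few. Any claim that something is new, unique, unknown or untested is made for them only; others in the source may bear on it.

In a functional assay on B16 cells (Mus musculus) for cytotoxicity, read by MTT assay, with a stated time of 48 h (a lower number here means a stronger inhibitor, a higher number a weaker inhibitor), compound 1 `CC1(C)OC[C@H](Cn2cc(-c3ccc4ccccc4c3)nn2)O1` gives 12000 nM. Compound 3 `OCCCn1cc(-c2ccc3ccccc3c2)nn1` reaches only the limit of this assay, > 100000 nM. Compound 2 `OCCCn1cc(-c2ccc(C(F)(F)F)cc2)nn1` likewise sits at a limit, > 100000 nM. Two of the three values thus rest on (the limit of > 100000 nM in this assay, at which 2 of the 3 values shown sit). The change 2,2-dimethyl-1,3-dioxolan-4-yl in place of 2-hydroxyethyl on a saturated chain carbon bound to an aromatic nitrogen produced an at least 8.3-fold lower number from compound 3 to compound 1 (0.92 log units; beyond the scatter). How the core of compound 2 differs from that of compound 3 is not broken down here. Compound 4 `CC1(C)OC[C@H](Cn2cc(-c3ccc(C(F)(F)F)cc3)nn2)O1` carries the same change as compound 2, namely (2,2-dimethyl-1,3-dioxolan-4-yl in place of 2-hydroxyethyl on a saturated chain carbon bound to an aromatic nitrogen). Since compound 2 only shows a limit, the starting point is uncertain, and an improvement of the same kind is expected, an at least 2.5-fold lower number from compound 2 to compound 4 (0.39 log units; beyond the scatter). Compound 4 is therefore estimated at 40000 nM, with a range from 8000 nM to 150000 nM.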

Compound 4, half-maximal inhibitory concentration: > 100000 nM
Compound 4: only a limit was reported; the forecaster's own chance of this, stated with the estimate: 45%; middle value at least 2.5-fold (0.39 log units) away from the limit.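

Compound 2 and compound 4 both rest on a limit rather than a number, so no step can be read between them: the limit of > 100000 nM in this assay, at which 3 of the 4 values shown sit.

The compounds shown leave open whether 2,2-dimethyl-1,3-dioxolan-4-yl in place of 2-hydroxyethyl lowers the number at all on the core of compound 4, as it does on the core of compound 1.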